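The compounds below may be only part of what the source reports. "The series", "measured", "known", "first", "only" and "open" are said of these compounds alone.

Compound 1 `CC1=CC[C@@H]([C@@](C)(O)CCCC(C)(C)NC(=S)N/N=C\c2ccc(C)cc2)CC1` gives 39000 nM in a functional assay on UACC-62 cells (Homo sapiens) for cytotoxicity, read by sulforhodamine B assay; a lower number here means a stronger inhibitor of growth, a higher number a weaker inhibitor of growth. Compound 2 `CC1=CC[C@@H]([C@@](C)(O)CCCC(C)(C)NC(=S)N/N=C\c2ccc([N+](=O)[O-])cc2)CC1` gives 62200 nM in this assay, the higher of the two numbers shown, with its gap to compound 1 within the scatter. Compound 3 `CC1=CC[C@@H]([C@@](C)(O)CCCC(C)(C)NC(=S)N/N=C\c2ccccc2Cl)CC1` differs from compound 2 by 2-chlorophenyl in place of 4-nitrophenyl on a carbon with a double bond to nitrogen. Among the compounds with values here, the only measured step that bears on this exchange of the group on the carbon with a double bond to nitrogen is a 1.6-fold higher number from compound 1 to compound 2 (0.20 log units; within the scatter). On that basis no step beyond the scatter is expected in this assay, and the expected step is a 1.4-fold lower number from compound 2 to compound 3 (0.14 log units; within the scatter). Compound 3 is therefore estimated at 45000 nM, between 15000 nM and 130000 nM.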

Compound 3, concentration for total growth inhibition: > 100000 nM
Compound 3 was reported as a limit; the forecaster's own chance of this, stated with the estimate: 10%; middle value at least 2.2-fold (0.34 log units) from the limit.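

In this assay compound 3 gives > 100000 nM, which is a limit and not a number. The group on the carbon with a double bond to nitrogen can still move the read-out beyond the scatter: 2-chlorophenyl in place of 4-methylphenyl gives an at least 2.5-fold higher number from compound 1 to compound 3 (0.40 log units; beyond the scatter). Against 4-nitrophenyl, the same exchange gives an at least 1.6-fold higher number from compound 2 to compound 3 (0.20 log units; that floor lies within the scatter), so that pair stays unseparated.

From the compounds shown here alone, the size of both steps remains open past the limit. Also open, going by these compounds, is whether the chlorine itself or its place on the ring carries the step, which a 4-chlorophenyl or plain phenyl group on this carbon would address.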